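The compounds below may be only part of what the source reports. "The series", "measured", "known", "first", "only" and "open" are said of these compounds alone.

Working notes on the series. Compound 1 `OC[C@H]1O[C@@H](n2cnc3c(NCc4ccccc4Cl)ncnc32)[C@H](O)[C@@H]1O` has no number in a functional assay on G-361 cells (Homo sapiens) for antiproliferative activity, with a stated time of 72 h; a lower number here means a stronger inhibitor, a higher number a weaker inhibitor; its entry reads "not determined" (no result reported). In this assay compound 2 `Cc1cccc(CNc2ncnc3c2ncn3[C@@H]2O[C@H](CO)[C@@H](O)[C@H]2O)c1` reaches only a limit of the assay, > 166000 nM. Compound 3 `Cc1ccc(CNc2ncnc3c2ncn3[C@@H]2O[C@H](CO)[C@@H](O)[C@H]2O)cc1` likewise gives "not determined" (no result reported) in this assay. Across the three entries one sits at the limit of > 166000 nM in this assay, at which 1 of the 3 values shown sits, and no step between measured compounds can be drawn, so compound 1 cannot be placed against the others. Compound 4 `OC[C@H]1O[C@@H](n2cnc3c(NCc4ccc(Cl)cc4Cl)ncnc32)[C@H](O)[C@@H]1O` differs from compound 1 by chloro in place of hydrogen on an aromatic carbon. Within the data shown here, with no measured step in this assay, no direction is expected for the change beyond the scatter. For compound 4 the potency in this assay is estimated at 120000 nM, within a range of 30000 nM to 400000 nM, with a real chance that only a limit is reported.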

Compound 4, half-maximal inhibitory concentration: 128000 nM
Estimate against measurement, compound 4: 1.1-fold (0.03 log units) below; the measured number falls inside the stated range.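

Among these compounds, compound 4 gives 128000 nM in this assay as the first single number. Compound 2 reads > 166000 nM as a limit of the assay and nothing more. The step reads an at least 1.2-fold lower number from compound 2 to compound 4 (0.11 log units; that floor lies within the scatter) and so does not establish a gain beyond the scatter for 2,4-dichlorophenyl in place of 3-methylphenyl, while the added chloro cannot be read on its own, as compound 1 has no number.

On these data alone, whether an amine or a carboxylic acid in place of this chloro, or a longer chain on the nitrogen, would move the number in this assay stays open.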